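This account rests on a few compounds, and the source may have more. Where it says the series, first, only, none or still open, it means among the compounds named here.

Measured compounds in the series:

Compound 1, `COc1ccc(/C=C2\CCC/C(=C\c3ccc(OC)c(OC)c3)C2=O)cc1`: 7200 nM
Compound 2, `COc1ccc(/C=C2\CCC/C(=C\c3ccc(OC)c(OC)c3)C2=O)c(OC)c1`: 17100 nM
Compound 3, `COc1cc(/C=C2\CCC/C(=C\c3ccc(OC)c(OC)c3)C2=O)cc(OC)c1`: 2600 nM

All three were run in a functional assay on HT-1080 cells (Homo sapiens) for cytotoxicity, read by MTT assay, with a stated time of 72 h; on this read-out lower numbers stand for stronger inhibition and higher numbers for weaker inhibition. Compound 3 gives the lowest number of the three, and its distance from compound 1 and from compound 2 is in each case beyond the scatter. The difference between the core of compound 3 and that of compound 1 is not broken down here.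

Among the compounds with values here, the one single-point change that is measured is methoxy in place of hydrogen on an aromatic carbon, which gave a 2.4-fold higher number from compound 1 to compound 2 (0.38 log units; beyond the scatter) in this assay.

The compound still to be measured is compound 4, `COc1ccc(/C=C2\CCC/C(=C\c3cc(OC)c(OC)c(OC)c3)C2=O)cc1OC`. It arises from compound 3 by methoxy in place of hydrogen on an aromatic carbon. This is the same kind of change as that from compound 1 to compound 2, but not the same: in the earlier pair the entering group sits ortho to a large group and meta to a methoxy group, whereas here it sits ortho to two methoxy groups and para to a large group.

Resting on the earlier step from compound 1 to compound 2, a rise in the number of comparable size is expected, with wider uncertainty given the different surroundings: for compound 4 the step is estimated as a 1.9-fold higher number from compound 3 to compound 4 (0.28 log units; within the scatter). Compound 4 is therefore estimated at 5000 nM in this assay, between 1800 nM and 14000 nM.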

Compound 4, half-maximal inhibitory concentration: 1100 nM
Compound 4: the middle estimate sits 4.5-fold (0.66 log units) above what was measured, outside the stated range (below it).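

Methoxy in place of hydrogen on an aromatic carbon gave a 2.4-fold lower number from compound 3 to compound 4 (0.37 log units; beyond the scatter) in this assay, so in this series the change does not carry over from one core to another with a single direction, and the two measured steps run opposite ways: the same change on two cores in this assay, a 2.4-fold higher number (0.38 log units; beyond the scatter) from compound 1 to compound 2 and a 2.4-fold lower number (0.37 log units; beyond the scatter) from compound 3 to compound 4, 5.6-fold (0.75 log units) apart, beyond the scatter of two such steps

This does not show what separates the two results, since the two pairs differ in their cores and also in the surroundings of the entering group, which here sits ortho to two methoxy groups and para to a large group. Two pairs give no rule for predicting the direction of this change on a further core, and they assign no cause to the reversal.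

The compounds shown leave open whether ethoxy, a longer chain, or hydroxyl at the place taken by the entering methoxy group would keep the lower number of compound 4. Also open, from the compounds shown here alone, is whether an amine or a carboxylic acid at that same place would fit the pattern of compound 3 and compound 4.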